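This account rests on a few compounds, and the source may have more. Where it says the series, first, only, none or still open, it means among the compounds named here.

Working notes on the series. The read-out is a functional assay on A549 cells (Homo sapiens) for inhibition, read by MTT assay, with a stated time of 48 h; a lower number here means a stronger inhibitor, a higher number a weaker inhibitor. Compound 1 `COc1cc(-c2nccn3cc(-c4ccc(N)cc4)nc23)cc(OC)c1OC` gives 287 nM in this assay. Compound 2 `COc1cc(-c2nccn3cc(-c4ccc(O)cc4)nc23)cc(OC)c1OC` reaches only the limit of > 10000 nM in this assay. Compound 3 `COc1cc(-c2nccn3cc(-c4ccc([N+](=O)[O-])cc4)nc23)cc(OC)c1OC` likewise returns only the limit of > 10000 nM in this assay, so compound 3 stands at the limit of > 10000 nM in this assay, at which 2 of the 3 values shown sit, and no number is known for it. The two steps from the amino compound are both large: an at least 34-fold higher number from compound 1 to compound 2 (1.54 log units; beyond the scatter) and an at least 34-fold higher number from compound 1 to compound 3 (1.54 log units; beyond the scatter). The step between the two limits, a step that the two limits leave unreadable from compound 2 to compound 3, cannot be sized.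

Compound 4 `COc1cc(-c2nccn3cc(-c4ccc5[nH]ccc5c4)nc23)cc(OC)c1OC` is the next member and is not yet measured. It differs from compound 3 as follows: 1H-indol-5-yl in place of 4-nitrophenyl on an aromatic carbon. Going by the values given here, the steps that bear on this change are the two large worsenings from compound 1 to compound 2 and to compound 3, in which both hydroxy and nitro sit at the limit, whereas only the amino compound gives a readable number. The indol-5-yl group has not been tried in this series, so the direction is expected with low confidence; a number below the limit of compound 3 is expected, with a wide range, corresponding to an at least 4.0-fold lower number from compound 3 to compound 4 (0.60 log units; beyond the scatter). Compound 4 is therefore estimated at 2500 nM, between 300 nM and 10000 nM.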

Compound 4, half-maximal inhibitory concentration: 154 nM
Beside the measured number, compound 4's estimate is 16-fold (1.21 log units) above it; measured number below the stated range.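

At this aromatic carbon of the five-membered ring, a readable number in this assay no longer belongs to the 4-aminophenyl group alone, since the 1H-indol-5-yl group also gives one, with an at least 64-fold lower number from compound 3 to compound 4 (1.81 log units; beyond the scatter) and an at least 64-fold lower number from compound 2 to compound 4 (1.81 log units; beyond the scatter). Against the amino compound the change gives a 1.9-fold lower number from compound 1 to compound 4 (0.27 log units; within the scatter), which lies within the scatter, so the 4-aminophenyl and 1H-indol-5-yl groups cannot be told apart here, and a fused bicyclic group of the same heavy-atom size as 4-nitrophenyl is accepted at this carbon. Compound 2 and compound 3 each remain a limit rather than a number, so the two large steps to compound 4 are minimum sizes and the step between compound 2 and compound 3 cannot be read: the limit of > 10000 nM in this assay, at which 2 of the 4 values shown sit.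

The compounds shown leave open whether the hydrogen on the indole nitrogen or on the amino group matters, a question that a 1-methyl-1H-indol-5-yl or a 4-(dimethylamino)phenyl group at this carbon would address. They also leave open whether other fused groups, such as 1H-indazol-5-yl or quinolin-6-yl, give readable numbers on the shared core.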